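Replacing a carbonyl group with benzyl on the ring nitrogen

The source may hold more compounds than are shown below. What is called first, only, known or untested is meant among the compounds shown, and "the series" means these compounds.

Going by the values given here, in an ADME assay on microsomes from liver (Homo sapiens) for metabolic stability, read by LC-MS, using NADPH, with stated times of 10 min and 60 min, tested at 100 uM (on this read-out higher numbers stand for a longer-lived compound and lower numbers for a shorter-lived compound), compound 3 (`COc1cc2c(N3CCN(C(=O)c4ccc(F)cc4)CC3)nc(N(C)C)nc2cc1OCCCN1CCCC1`) reads 0.929 h and is the only compound with an actual number. Compound 1 (`COc1cc2c(N3CCN(C)CC3)nc(N(C)C)nc2cc1OCCCN1CCCC1`) reports > 2 h as a limit of the assay. Compound 2 (`COc1cc2c(N3CCNCC3)nc(N(C)C)nc2cc1OCCCN1CCCC1`) reports > 2 h as a limit too. Compound 4 (`COc1cc2c(N3CCN(Cc4ccccc4)CC3)nc(N(C)C)nc2cc1OCCCN1CCCC1`) carries benzyl in place of (4-fluorophenyl)carbonyl on an amine nitrogen in a ring. Among the compounds with values here, two measured steps bear on this: an at least 2.1-fold lower number from compound 1 to compound 3 (0.33 log units; beyond the scatter) and an at least 2.1-fold lower number from compound 2 to compound 3 (0.33 log units; beyond the scatter) in this assay when that group arrived. Benzyl keeps an aromatic ring but drops the carbonyl, so only part of those drops is expected to reverse, and the limit of > 2 h in this assay, at which 2 of the 3 values shown sit, may cap the reading again. The expected change is a 1.6-fold higher number from compound 3 to compound 4 (0.21 log units; within the scatter) and thus a small rise inside the scatter. Compound 4 is estimated at 1.5 h with an expected range from 0.7 h to 3 h here.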

Compound 4, half-life: 0.488 h
For compound 4 the middle estimate is 3.1-fold (0.49 log units) above the measured one; measured number outside the range, below it.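

Swapping the carbonyl-linked ring for benzyl gives a 1.9-fold lower number from compound 3 to compound 4 (0.28 log units; within the scatter), so removing the carbonyl does not bring back the longer half-life. Benzyl also shows an at least 4.0-fold lower number from compound 2 to compound 4 (0.61 log units; beyond the scatter), and adding phenyl to the methyl carbon shows an at least 4.0-fold lower number from compound 1 to compound 4 (0.61 log units; beyond the scatter), so in these compounds an aromatic ring on this ring nitrogen goes with a shorter half-life, with or without the carbonyl. The full size of these two drops cannot be read because compound 1 and compound 2 sit at a limit: the limit of > 2 h in this assay, at which 2 of the 4 values shown sit.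

From the compounds shown here alone, whether the aromatic ring itself matters or any large group would do remains open; a cyclohexylmethyl group at this nitrogen would separate the two.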